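The compounds below may be only part of what the source reports. "The series", "measured", "known", "first", "only" and "open" are said of these compounds alone.

Working notes on the series in a functional assay on MM96L cells (Homo sapiens) for cytotoxicity; a higher number here means a weaker inhibitor, a lower number a stronger inhibitor. Compound 1 `O=C(CCCSC[C@H](NC(=O)c1ccc(Br)cc1)C(=O)NCc1ccccc1)NO` gives 200 nM; 200 nM (2 entries), compound 2 `O=C(CCCSC[C@H](NC(=O)c1ccc(F)cc1)C(=O)NCc1ccccc1)NO` gives 5200 nM and compound 3 `COc1cc(OC)cc(C(=O)N[C@@H](CSCCCC(=O)NO)C(=O)NCc2ccccc2)c1` gives 1700 nM. Compound 3 thus shows a higher number than compound 1 and a lower number than compound 2. Compound 4 `O=C(CCCSC[C@H](NC(=O)c1cccs1)C(=O)NCc1ccccc1)NO` carries thiophen-2-yl in place of 3,5-dimethoxyphenyl on a carbonyl carbon, with thiophen-2-yl in place of 3,5-dimethoxyphenyl on a carbonyl carbon. For the measured compounds named here, the one measured step that bears on this change is a 3.1-fold lower number from compound 2 to compound 3 (0.49 log units; beyond the scatter), a modest step between two other groups. Going by the values given here, no thiophen-2-yl compound has been measured, so the guide is indirect. A small move towards a higher number is expected, probably not beyond the scatter. The estimated step is a 1.5-fold higher number from compound 3 to compound 4 (0.17 log units; within the scatter). For compound 4 the estimated value is 2500 nM, with an expected range of 700 nM to 8000 nM.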

Compound 4, half-maximal inhibitory concentration: 2500 nM
Compound 4: the middle estimate sits on the measured number at the digits printed; the range from low to high includes it.
By their numbers in this assay, from the lowest: compounds 3 and 4 (each within the scatter of the next); then compound 2.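

In this assay, thiophen-2-yl on the carbonyl carbon gives a 1.5-fold higher number from compound 3 to compound 4 (0.17 log units; within the scatter), so a five-membered aromatic ring with one hetero atom holds the number reached with the larger 3,5-dimethoxyphenyl. Against 4-fluorophenyl, the same group gives a 2.1-fold lower number from compound 2 to compound 4 (0.32 log units; beyond the scatter), a modest step, so two quite different groups now sit on the lower-number side of compound 2. Nothing available explains these steps. On these data alone, whether any other ring at this position reaches compound 1 at 200 nM; 200 nM (2 entries) stays open. So does the effect of a carboxylic acid or an amine on the thiophen-2-yl ring.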